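From pyridin-3-yl to pyridin-4-yl in a cell toxicity test

The source may report more compounds than this note shows. Statements on the series, on what has been measured and on what is new or still open speak of the compounds shown alone.

- Compound 1 `O=C1/C(=C/c2cccnc2)CN(S(=O)(=O)c2ccc([N+](=O)[O-])cc2)C/C1=C\c1ccccc1F` gives > 20000 nM as a limit
- Compound 2 `N#Cc1ccc(S(=O)(=O)N2C/C(=C\c3cccnc3)C(=O)/C(=C/c3ccccc3F)C2)cc1` gives > 20000 nM as a limit

In an ADME assay on L02 cells (Homo sapiens) for cytotoxicity, read by MTT assay, with a stated time of 24 h (on this read-out lower numbers stand for stronger inhibition and higher numbers for weaker inhibition), compound 1 gives > 20000 nM as a limit and not a number. Compound 2 gives > 20000 nM as a limit too. The two measurements have this in common: the limit of > 20000 nM in this assay, at which 2 of the 2 values shown sit, and nothing finer can be read from them. Among the compounds with values here, the only measured step is a step that the two limits leave unreadable from compound 1 to compound 2 and it puts cyano in place of nitro, a different change, so it offers no size to carry over.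

Compound 3 `O=C1/C(=C/c2ccncc2)CN(S(=O)(=O)c2ccc([N+](=O)[O-])cc2)C/C1=C\c1ccccc1F` has the same atoms as compound 1, joined differently: pyridin-4-yl in place of pyridin-3-yl on a double-bonded chain carbon bound to a double-bonded ring carbon with pyridin-4-yl in place of pyridin-3-yl on a double-bonded chain carbon bound to a double-bonded ring carbon.

The expectation rests on compound 1 and its limit of > 20000 nM alone. No step beyond the usual scatter is expected in this assay in either direction. The estimated step is a step that the limit leaves unreadable from compound 1 to compound 3 and a result that is only a limit is the likeliest expected outcome. For compound 3 the expected value is 25000 nM with 12000 nM to 60000 nM as the estimated range.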

Compound 3, half-maximal inhibitory concentration: 18400 nM
Beside the measured number, compound 3's estimate is 1.4-fold (0.13 log units) above it, within the range that was stated.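

Within the data shown here, putting pyridin-4-yl in place of pyridin-3-yl on a double-bonded chain carbon bound to a double-bonded ring carbon gives the first real number in this assay, where the earlier compounds offered only this: the limit of > 20000 nM in this assay, at which 2 of the 3 values shown sit. Going by these compounds, the change reads as an at least 1.0-fold lower number from compound 1 to compound 3 (0.03 log units; that floor lies within the scatter), and compound 1 has only a limit, so the true size of the step stays unknown and could be close to nothing. The two compounds have the same atoms, joined differently, which makes this a clean test of one swap, yet the result does not establish that the swap alters cytotoxicity.

On these data alone, whether pyridin-4-yl would give a number alongside the cyano group of compound 2 remains open. So does how an amine or a carboxylic acid at this place would read in this assay.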